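The compounds below may be only part of what the source reports. "The series", "measured", "known", "first", "only" and "open" are said of these compounds alone.

Compound 1 `Cc1nc(N)nc(N[C@@H]2C[C@H](CO)[C@@H](O)[C@H]2O)c1-c1nc2ccccc2s1`: 4000 nM
Compound 2 `COCCNc1nc(C)c(-c2nc3ccccc3s2)c(N[C@@H]2C[C@H](CO)[C@@H](O)[C@H]2O)n1`: 21000 nM
Compound 3 `Cc1nc(NCc2ccccc2)nc(N[C@@H]2C[C@H](CO)[C@@H](O)[C@H]2O)c1-c1nc2ccccc2s1`: 9000 nM

In an ADME assay on cells (Homo sapiens) for cytotoxicity, read by polymerase chain reaction, with a stated time of 3 days (a lower number here means that less compound is tolerated, a higher number that more compound is tolerated), compound 3 stands second highest of the three numbers. Its nearest neighbour is compound 1, and the step of a 2.3-fold higher number from compound 1 to compound 3 (0.35 log units; beyond the scatter) lies beyond the scatter. Its furthest neighbour is compound 2, and the step of a 2.3-fold lower number from compound 2 to compound 3 (0.37 log units; beyond the scatter) also lies beyond the scatter. The remaining measured step, a 5.3-fold higher number from compound 1 to compound 2 (0.72 log units; beyond the scatter), completes the small set.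

Compound 4 `Cc1nc(NCc2ccncc2)nc(N[C@@H]2C[C@H](CO)[C@@H](O)[C@H]2O)c1-c1nc2ccccc2s1` differs from compound 3 in one place: pyridin-4-yl in place of phenyl on a saturated chain carbon bound to a nitrogen on an aromatic ring. For the measured compounds named here, only one measured step concerns the same place, a 2.3-fold lower number from compound 2 to compound 3 (0.37 log units; beyond the scatter), and it was modest; the two other steps alter a different part of the shared core. A modest upward step is expected for compound 4 because a 2.3-fold lower number from compound 2 to compound 3 (0.37 log units; beyond the scatter) ran downward when a group carrying one hydrogen-bond acceptor left that place, and the entering pyridin-4-yl again brings one acceptor. The estimate for compound 4 is 13000 nM, within 6000 nM to 28000 nM, which means an expected step of a 1.4-fold higher number from compound 3 to compound 4 (0.16 log units; within the scatter).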

Compound 4, half-maximal cytotoxic concentration: 7000 nM
The estimate for compound 4 lay 1.9-fold (0.27 log units) above the measured number; low and high end bracket the measured number.
By their numbers in this assay, from the lowest: compounds 1, 4 and 3 (each within the scatter of the next, the first and the last beyond it); then compound 2.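

In this assay, replacing phenyl with pyridin-4-yl on a saturated chain carbon bound to a nitrogen on an aromatic ring gives a 1.3-fold lower number from compound 3 to compound 4 (0.11 log units; within the scatter), so this change of ring has no readable effect on the number. The hydrogen-bond acceptor that pyridin-4-yl brings does not by itself reproduce the number of compound 2, as a 3.0-fold lower number from compound 2 to compound 4 (0.48 log units; beyond the scatter) shows. Compound 4 also sits closer to the unsubstituted amine, with a 1.8-fold higher number from compound 1 to compound 4 (0.24 log units; within the scatter), whereas the benzyl group gave a 2.3-fold higher number from compound 1 to compound 3 (0.35 log units; beyond the scatter), though compound 3 and compound 4 cannot themselves be told apart.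

Nothing shown here accounts for these steps.

Going by these compounds, whether a carboxylic acid, or a longer chain ending in an amine, at this place would move the number beyond the scatter from compound 3 stays open.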